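Triazole nitrogen substituent and A549 inhibition

The source may hold more compounds than are shown below. What is called first, only, known or untested is meant among the compounds shown, and "the series" means these compounds.

Measured so far in a functional assay on A549 cells (Homo sapiens) for inhibition, read by MTT assay; on this read-out lower numbers stand for stronger inhibition and higher numbers for weaker inhibition:
compound 1 `CCCCCCCCn1cc(/C=C/C(=O)c2ccc(NC(=O)CN3CCN(C(=O)OC(C)(C)C)CC3)cc2)nn1`: 43300 nM
compound 2 `CC(C)(C)OC(=O)N1CCN(CC(=O)Nc2ccc(C(=O)/C=C/c3cn(Cc4ccc(Br)cc4)nn3)cc2)CC1`: 38400 nM

Among the compounds with values here, compound 2 gives the lowest of the two numbers in this assay, with compound 1 nearest, and the only measured step, a 1.1-fold lower number from compound 1 to compound 2 (0.05 log units; within the scatter), lies within the scatter. Compound 3 `CCCCCCCCCCn1cc(/C=C/C(=O)c2ccc(NC(=O)CN3CCN(C(=O)OC(C)(C)C)CC3)cc2)nn1` differs from compound 2 by nonyl in place of 4-bromophenyl on a saturated chain carbon bound to an aromatic nitrogen. This returns to an unbranched chain as in compound 1, nonyl rather than heptyl. Since the heptyl-to-aryl step was within the scatter, no step beyond the scatter is expected for a 1.0-fold higher number from compound 2 to compound 3 (0.02 log units; within the scatter). Compound 3 is therefore estimated at 40000 nM in this assay, within 18000 nM to 90000 nM.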

Compound 3, half-maximal inhibitory concentration: 45400 nM
Estimate against measurement, compound 3: 1.1-fold (0.05 log units) below; the range from low to high includes it.
By their numbers in this assay, from the lowest: compounds 2, 1 and 3 (each within the scatter of the next).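

Nonyl in place of 4-bromophenyl gives a 1.2-fold higher number from compound 2 to compound 3 (0.07 log units; within the scatter), and ethyl in place of hydrogen on the chain gives a 1.0-fold higher number from compound 1 to compound 3 (0.02 log units; within the scatter), so in this assay neither change leaves the scatter. At this position, compounds 1, 2 and 3 therefore do not separate, whether the substituent holds an aromatic ring or only a chain. No measured evidence bears on this result.
Open, from the compounds shown here alone, is whether a chain ending in an amine or a carboxylic acid would separate from these three. Going by these compounds, a methyl group at this position is equally open.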